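Methanesulfonamido in place of methoxy on compound 1

A few compounds are considered here, and "the series" means these few. Any claim that something is new, unique, unknown or untested is made for them only; others in the source may bear on it.

Measured so far in a functional assay on HeLa cells (Homo sapiens) for cytotoxicity, read by resazurin assay, with a stated time of 72 h; a lower number here means a stronger inhibitor, a higher number a weaker inhibitor:
compound 1 `CCSC(=S)SCC(=O)c1ccc(OC)cc1` gives 1960 nM 
compound 2 `CCCC(=S)SCC(=O)c1ccc(OC)cc1` gives 5710 nM 
compound 3 `CCOC(=O)SCC(=O)c1ccc(OC)cc1` gives 18500 nM 

Compound 1 has the lowest number of the three and is the strongest inhibitor among them. The measured steps are modest: a 2.9-fold higher number from compound 1 to compound 2 (0.46 log units; beyond the scatter) then a 3.2-fold higher number from compound 2 to compound 3 (0.51 log units; beyond the scatter) and across the whole span a 9.4-fold higher number from compound 1 to compound 3 (0.97 log units; beyond the scatter) in this series.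

Compound 4 `CCSC(=S)SCC(=O)c1ccc(NS(C)(=O)=O)cc1` differs from compound 1 at the other end of the molecule, with methanesulfonamido in place of methoxy on an aromatic carbon. All three measured steps change the group on the sulfur, so none tests this exchange directly, and they offer only a rough guide to size. Compound 1 at 1960 nM is already the lowest value, so a modest move towards a higher number seems more likely than a further fall, though the data do not settle the direction. The expected change is a 2.0-fold higher number from compound 1 to compound 4 (0.31 log units; beyond the scatter) in this assay as an estimate only. For compound 4 the estimated value is 4000 nM with an expected range from 1000 nM to 15000 nM in this assay for now.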

Compound 4, half-maximal inhibitory concentration: 45800 nM
The estimate for compound 4 lay 11-fold (1.06 log units) below the measured number, outside the stated range (above it).
By their numbers in this assay, from the lowest: compound 1; then compound 2; then compound 3; then compound 4.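

In this assay, the aromatic end of the molecule proved far less tolerant than the sulfur end: exchanging methoxy for methanesulfonamido gave a 23-fold higher number from compound 1 to compound 4 (1.37 log units; beyond the scatter), a large step, while the widest exchange on the sulfur gave only a 9.4-fold higher number from compound 1 to compound 3 (0.97 log units; beyond the scatter). This aromatic carbon is therefore not a neutral place for substitution, at least for this exchange on the core of compound 1. Nothing available explains the loss, which came with a larger group that carries a hydrogen-bond donor.

On these data alone, whether the rise comes from losing methoxy or from gaining methanesulfonamido remains open, and an amine or a hydroxyl on that aromatic carbon would help separate the two. Also open, as far as these compounds go, is whether the same exchange would cost as much with the propyl group of compound 2 or the ethoxy-bearing carbonyl of compound 3.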